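A few compounds are considered here, and "the series" means these few. Any claim that something is new, unique, unknown or untested is made for them only; others in the source may bear on it.

Measured in a functional assay on a cell-free system (plasma, Homo sapiens) for inhibition, with Plasma (Rattus norvegicus) as the target; a lower number here means a stronger inhibitor, a higher number a weaker inhibitor:
- compound 1 `O=c1cc(N2CCNCC2)oc2ccccc12`: 56000 nM
- compound 2 `O=c1cc(N2CCNCC2)c2ccc(OCc3ccccc3)cc2o1`: 16300 nM
- compound 3 `Cc1c(OCc2ccccc2)ccc2c(N3CCNCC3)cc(=O)oc12`: 1900 nM

Of these three, compound 3 has the lowest number, 1900 nM, which marks it as the strongest inhibitor measured so far. Compound 4 `Cc1c(OCc2cccnc2)ccc2c(N3CCNCC3)cc(=O)oc12` differs from compound 3 in one ring: pyridin-3-yl in place of phenyl on a saturated chain carbon bound to an oxygen on an aromatic ring. Here pyridin-3-yl takes the place of phenyl on a saturated chain carbon bound to an oxygen on an aromatic ring, turning benzyloxy into (pyridin-3-yl)methoxy.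

For the measured compounds named here, the only measured step with a single change is an 8.6-fold lower number from compound 2 to compound 3 (0.93 log units; beyond the scatter), with methyl in place of hydrogen on an aromatic carbon. That step shows that one small edit can shift the number in this assay beyond the scatter. However, it involves a different group and gives no direction for this swap, and no measured compound carries pyridin-3-yl. With no evidence for a direction, the expected step is small and uncertain: a 1.3-fold higher number from compound 3 to compound 4 (0.12 log units; within the scatter). Compound 4 is estimated at 2500 nM, with an expected range from 700 nM to 9000 nM.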

Compound 4, half-maximal inhibitory concentration: 980 nM
Compound 4: the middle estimate sits 2.6-fold (0.41 log units) above what was measured; the measured number falls inside the stated range.
By their numbers in this assay, from the lowest: compounds 4 and 3 (each within the scatter of the next); then compound 2; then compound 1.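

In this assay, for the compounds shown here, the earlier compounds all carry phenyl at this place, so they say nothing about changing that ring. Putting pyridin-3-yl in place of phenyl on the saturated chain carbon brings in one ring nitrogen and one hydrogen-bond acceptor, and it gives a 1.9-fold lower number from compound 3 to compound 4 (0.29 log units; within the scatter), so the two compounds cannot be told apart in this assay and the ring at this place accepts this swap without a clear shift in the number. The data offer no measurement that would explain this outcome.

The compounds shown leave open whether the ring nitrogen would matter as pyridin-2-yl or pyridin-4-yl, or with an amine or a carboxylic acid on the ring. They also leave open how a longer chain between the oxygen and the ring would behave.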